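The compounds below may be only part of what the source reports. "The series", "measured", "known", "first", "only" and "open" are said of these compounds alone.

Measured in a functional assay on SK-OV-3 cells (Homo sapiens) for inhibition, read by CCK-8 assay, with a stated time of 70 h (on this read-out higher numbers stand for weaker inhibition and lower numbers for stronger inhibition), so far:
compound 1 (`c1ccc(COc2ccc(OCCOCCNC3CCCC3)cc2)cc1`) gives 24800 nM
compound 2 (`COc1ccc(COc2ccc(OCCOCCNC3CCCC3)cc2)cc1`) gives 15700 nM
compound 3 (`Clc1ccc(COc2ccc(OCCOCCNC3CCCCC3)cc2)cc1`) gives 2650 nM

Compound 2 stands second highest of these three numbers, close to compound 1 and clearly above compound 3. Compound 4 (`O=C(O)c1ccccc1COc1ccc(OCCOCCNC2CCCC2)cc1`) carries 2-carboxyphenyl in place of 4-methoxyphenyl on a saturated chain carbon bound to an oxygen on an aromatic ring. Among the measured compounds shown here, the one measured step bearing on this is methoxy in place of hydrogen (a 1.6-fold lower number from compound 1 to compound 2 (0.20 log units; within the scatter)), and it lies within the scatter. For the measured compounds named here, no measured compound has a carboxyl group, so that step guides only loosely. In this assay a small step is expected, with an assumed lean toward weaker inhibition (a 1.6-fold higher number from compound 2 to compound 4 (0.20 log units; within the scatter)). Compound 4 is estimated at 25000 nM (expected range 9000 nM to 70000 nM).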

Compound 4, half-maximal inhibitory concentration: > 100000 nM
Compound 4: only a limit was reported (the forecaster's own chance of this, stated with the estimate: 20%); middle value at least 4.0-fold (0.60 log units) away from the limit.
By their numbers in this assay, from the lowest: compound 3; then compounds 2 and 1 (each within the scatter of the next). At a limit, above all of these: compound 4.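

This position does not tolerate every change: 2-carboxyphenyl in place of 4-methoxyphenyl gives an at least 6.3-fold higher number from compound 2 to compound 4 (0.80 log units; beyond the scatter) in this assay, and a carboxy group where hydrogen stood gives an at least 4.0-fold higher number from compound 1 to compound 4 (0.60 log units; beyond the scatter). Methoxy in place of hydrogen had stayed within the scatter, so this is the first change at this position shown to weaken inhibition clearly. The reading for compound 4 is a limit of the assay, not a number: the limit of > 100000 nM in this assay, at which 1 of the 4 values shown sits.

Going by these compounds, whether a methyl ester or a primary amide in place of the carboxylic acid would weaken inhibition as well stays open.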